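The compounds below may be only part of what the source reports. "The series", "measured", "known", "first", "only" and "open" are said of these compounds alone.

Compound 1 `COc1cc2nc([S+]([O-])CC(=O)Nc3ccc(C(F)(F)F)cc3)nc(Nc3c(C)cc(/C=C/C#N)cc3C)c2cc1OC` and compound 2 `COc1cc2nc([S+]([O-])CC(=O)Nc3ccccc3F)nc(Nc3c(Cl)cc(/C=C/C#N)cc3Cl)c2cc1OC` share one core and differ in the anilide and in the halogen or methyl substituents on the other aromatic ring. In an ADME assay on MT4 cells (Homo sapiens) for cytotoxicity, read by MTT assay, with a stated time of 5 days (a higher number here means that more compound is tolerated, a lower number that less compound is tolerated), compound 1 gives 52200 nM. For compound 2 the result in this assay is only a limit, > 208000 nM, so compound 2 stands without a number of its own. That limit is described by the limit of > 208000 nM in this assay, at which 1 of the 2 values shown sits. Compound 3 `COc1cc2nc([S+]([O-])CC(=O)Nc3cc([N+](=O)[O-])ccc3F)nc(Nc3c(Cl)cc(/C=C/C#N)cc3Cl)c2cc1OC` has not yet been tested in this assay. It differs from compound 2 in one place: nitro in place of hydrogen on an aromatic carbon. Going by the values given here, no measured pair that differs in a single place is available here, so the size of such a change has no precedent in this set, and the two known values do not form a step that can be read in either direction. The step from compound 2 to compound 3 is expected to be an at least 1.3-fold lower number from compound 2 to compound 3 (0.14 log units; that floor lies within the scatter), which is to say no change beyond the usual scatter in this assay. Compound 3 is therefore estimated at 150000 nM, within a range from 50000 nM to 300000 nM.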

Compound 3, half-maximal cytotoxic concentration: > 194000 nM
Compound 3: no number, only a limit; the forecaster's own chance of this, stated with the estimate: 55%; middle value at least 1.2-fold (0.11 log units) from the limit.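

In this assay, going by these compounds alone, compound 3, like compound 2, gives only a limit and no number of its own, so no step between compound 2 and compound 3 can be read. The compounds shown leave open whether nitro in place of hydrogen on this aromatic carbon shifts the tolerated concentration at all.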